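The compounds below may be only part of what the source reports. "The series", "measured", "known", "first", "only" and "open" are said of these compounds alone.

Working notes on the series.

Of the compounds shown here, two of the shared core have been measured in an assay on cell membranes for displacement of a labelled ligand from metabotropic glutamate receptor 5 (Rattus norvegicus); a lower number here means a stronger inhibitor, a higher number a weaker inhibitor. Compound 1, `O=C(Cc1ccc(F)cc1)c1sc2ncccc2c1-c1ccc(F)cc1`, gives 140 nM. Compound 2, `COc1ccc(CCC(=O)c2sc3ncccc3c2-c2ccccc2)cc1`, gives 2500 nM. On these two numbers compound 2 stands highest; compound 1 sits at a lower number, and the gap between the two lies beyond the usual scatter. The two structures differ in more than one place, so nothing can be drawn from that gap for any single change.

Compound 3, `O=C(CCc1ccc(F)cc1)c1sc2ncccc2c1-c1ccccc1`, has not yet been measured. It differs from compound 2 in one place: fluoro in place of methoxy on an aromatic carbon. For the measured compounds named here, the only other compound in hand that carries fluoro on such a ring is compound 1, which gives the lower number, but it differs from compound 3 in other places as well, so the size of the step from compound 2 to compound 3 has no direct precedent.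

The expectation is a modest move toward a lower number, of size a 2.5-fold lower number from compound 2 to compound 3 (0.40 log units; beyond the scatter). Compound 3 is estimated at 1000 nM, with a range from 300 nM to 3000 nM.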

Compound 3, inhibition constant: 343 nM
Estimate against measurement, compound 3: 2.9-fold (0.46 log units) above; measured number inside the range.
By their numbers in this assay, from the lowest: compound 1; then compound 3; then compound 2.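

In this assay, the change from 4-methoxyphenyl to 4-fluorophenyl gives a 7.3-fold lower number from compound 2 to compound 3 (0.86 log units; beyond the scatter), so the group on this aromatic carbon, para to a large group, affects the number by itself, with the rest of the structure held constant. For the compounds shown here, the earlier pair could not show this, as compound 1 and compound 2 differ in more than one place; this is the first step that can be read for a single change, and it shows that methoxy and fluoro are not interchangeable here. Nothing in hand gives a reason for this step, which stands as an observation only.

The compounds shown leave open whether hydrogen, chloro, hydroxyl or an amine on this carbon would sit nearer compound 2 or compound 3, and therefore whether the step reflects the arrival of fluoro or the departure of methoxy. Also open, as far as these compounds go, is whether the same change would give a step of similar size on a longer chain, as compound 1 differs from compound 3 in more than one place and cannot answer that.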